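The source may report more compounds than this note shows. Statements on the series, on what has been measured and on what is new or still open speak of the compounds shown alone.

Of the compounds shown here, two have been measured so far. Compound 1, with the structure `O=S(=O)(c1ccc(F)cc1)c1cnc2cc(F)c(Cl)cc2c1-c1ccc(Cl)cc1`, and compound 2, with the structure `O=S(=O)(c1ccc(F)cc1)c1cnc2cc(F)ccc2c1-c1ccc(F)cc1`, were both tested in an ADME assay on microsomes from liver (Homo sapiens) for metabolic stability, tested at 2.5 uM; on this read-out higher numbers stand for fast clearance and lower numbers for slow clearance. In this assay compound 1 gives 0.01 mL/min, while compound 2 gives 1.34 mL/min, the higher of the two numbers and well beyond the usual scatter; the two structures differ in more than one place, so these values can only be set side by side, not traced to a single change.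

Compound 3, with the structure `O=S(=O)(c1ccc(F)cc1)c1cnc2cc(F)ccc2c1-c1ccc(Cl)cc1`, has not yet been measured. Compared with compound 2, the difference is chloro in place of fluoro on an aromatic carbon. Within the data shown here, no measured pair shows this single change on its own, so there is nothing to read a step from directly. The expectation is that the step from compound 2 to compound 3 in this assay is small, a 1.5-fold lower number from compound 2 to compound 3 (0.17 log units; within the scatter), pointing slightly toward slower clearance but not clearly beyond the scatter. On that basis compound 3 is estimated to give 0.9 mL/min in this assay, with a likely range from 0.3 mL/min to 2.5 mL/min.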

Compound 3, intrinsic clearance in a liver preparation (reported as CLH), per the amount of preparation that the assay uses: 1.23 mL/min
Compound 3: middle estimate off by 1.4-fold (0.14 log units), on the low side; low and high end bracket the measured number.
By their numbers in this assay, from the lowest: compound 1; then compounds 3 and 2 (each within the scatter of the next).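

In this assay, the change from 4-fluorophenyl to 4-chlorophenyl gives a 1.1-fold lower number from compound 2 to compound 3 (0.04 log units; within the scatter), so at this position, para to a large group, these two halogens cannot be told apart on this read-out. Among these compounds, a change on the shared core behaves very differently: hydrogen in place of chloro on an aromatic carbon gives a 120-fold higher number from compound 1 to compound 3 (2.09 log units; beyond the scatter), which makes it the first single change here with a large step and shows that this chloro on the core matters far more in this pair than the choice of halogen on the phenyl ring does in the other. Nothing available here explains why one change is so large and the other so small.

As far as these compounds go, it remains open whether a different kind of group on the phenyl ring, such as methoxy, an amine or a carboxylic acid, would also leave the number within the scatter. From the compounds shown here alone, it is also open whether the large step is specific to chloro, or whether methyl or a nitrile on that carbon of the core would give a similar result.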